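The source may report more compounds than this note shows. Statements on the series, on what has been measured and on what is new or still open speak of the compounds shown alone.

Working notes on the series. Compound 2 `O=c1cc(CC(O)COCc2ccccc2)[nH]c(=O)[nH]1` sits at the limit of the assay in a functional assay on MCF7 cells (Homo sapiens) for antiproliferative activity, read by MTT assay, with a stated time of 72 h (a higher number here means a weaker inhibitor, a lower number a stronger inhibitor), where compound 2 gives > 100000 nM. Compound 3 `Cc1c(CC(O)COCc2ccccc2)[nH]c(=O)[nH]c1=O` likewise reaches only a limit in this assay, > 100000 nM. Compound 1 `C[Si](C)(C)CCOCn1c(CC(O)(COCc2ccccc2)COCc2ccccc2)cc(=O)[nH]c1=O` also returns a limit of > 100000 nM in this assay. Compound 1 carries the same group on the aromatic nitrogen that compound 4 carries. The only single-place step shown, a step that the two limits leave unreadable from compound 2 to compound 3, cannot be read because of the limit of > 100000 nM in this assay, at which 3 of the 3 values shown sit. Compound 4 `C[Si](C)(C)CCOCn1c(CC(O)COCc2ccccc2)cc(=O)[nH]c1=O` differs from compound 2 by a group of 8 heavy atoms (6 carbon, 1 oxygen, 1 silicon; no ring) in place of a hydrogen atom, on an aromatic nitrogen. Among the measured compounds shown here, no measured step bears on this change, and compound 1 gives no sign that the group brings measurable activity. Compound 4 is therefore expected to stay at the limit, with an expected step of a number no higher from compound 2 to compound 4 (the limit leaves the size open) and an estimate of 100000 nM (range 30000 nM to 300000 nM).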

Compound 4, half-maximal inhibitory concentration: > 100000 nM
Compound 4: no number, only a limit (the forecaster's own chance of this, stated with the estimate: 85%); the middle value lies on the limit itself.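

No new step can be read from compound 4 to compound 2 or compound 1, because each value is a limit and not a number: the limit of > 100000 nM in this assay, at which 4 of the 4 values shown sit. The compounds shown leave open which change to the shared core, if any, would give a measurable value.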